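The compounds below may be only part of what the source reports. "The series", "measured", "known", "first", "only" and "open" are said of these compounds alone.

Compound 1, `N#CC1=C(N)Oc2c(c3nc4ccccc4nc3c3ccccc23)C12C(=O)N(Cc1cnnn1-c1ccc([N+](=O)[O-])cc1)c1ccccc12`, in a functional assay on HepG2 cells (Homo sapiens) for antiproliferative activity, read by MTT assay, with a stated time of 48 h (on this read-out lower numbers stand for stronger inhibition and higher numbers for weaker inhibition), gives only the assay limit of > 50000 nM.
Compound 2, `N#CC1=C(N)Oc2c(c3nc4ccccc4nc3c3ccccc23)C12C(=O)N(Cc1cnnn1-c1ccc(S(N)(=O)=O)cc1)c1ccccc12`, in this assay gives 42200 nM.

Among the measured compounds shown here, compound 2 holds the only real number in this assay; the one further value is a limit, and the limit of > 50000 nM in this assay, at which 1 of the 2 values shown sits, marks where that limit sits. For the measured compounds named here, the single measured step, an at least 1.1-fold lower number from compound 1 to compound 2 (0.07 log units; that floor lies within the scatter), is tied to that limit and says little beyond it.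

Compound 3, `Cc1ccc(Cl)cc1-n1nncc1CN1C(=O)C2(C(C#N)=C(N)Oc3c2c2nc4ccccc4nc2c2ccccc32)c2ccccc21`, differs from compound 2 at the aryl group on the triazole nitrogen: 5-chloro-2-methylphenyl in place of 4-sulfamoylphenyl on an aromatic nitrogen. No measured step exchanges the whole aryl group, and the one step shown, which swaps sulfamoyl for nitro on an aromatic carbon, has a floor that lies within the scatter. The data therefore give no ground to expect a change beyond the scatter in either direction in this assay.

For compound 3 the expected value in this assay is 40000 nM, within a range of 15000 nM to 120000 nM, which corresponds to an expected step of a 1.1-fold lower number from compound 2 to compound 3 (0.02 log units; within the scatter).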

Compound 3, half-maximal inhibitory concentration: > 50000 nM
Compound 3 ended at the assay's limit; the forecaster's own chance of this, stated with the estimate: 40%; middle value at least 1.2-fold (0.09 log units) away from the limit.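

In this assay the exchange of 4-sulfamoylphenyl for 5-chloro-2-methylphenyl on the aromatic nitrogen gives an at least 1.1-fold higher number from compound 2 to compound 3 (0.07 log units; that floor lies within the scatter). This shows that the position can take an aryl group of a different make-up, with no hydrogen-bond donors or acceptors, and still yield no gain that can be read; the floor of this step lies within the scatter, so the sulfamoyl group cannot be said to matter. Compound 3 gives a limit and not a number, the step from compound 1 to compound 3 cannot be read, and compound 2 keeps the only real number, so the series is still bounded by a single value: the limit of > 50000 nM in this assay, at which 2 of the 3 values shown sit.

On these data alone, what remains open is whether any group on this triazole nitrogen can move the number beyond the scatter from compound 2, or whether the shared core holds every member near the limit. A phenyl ring bearing an amine or a carboxylic acid, or a longer alkyl chain in place of the aryl group, would put that question to the test.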